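Hydrazone series: aryl change on the carbonyl carbon

A few compounds are considered here, and "the series" means these few. Any claim that something is new, unique, unknown or untested is made for them only; others in the source may bear on it.

Measured so far:
compound 1 `Cc1cc2c(cc1C)C(Cl)=C(/C=N/NC(=O)c1ccccc1)CCC2` — > 100000 nM (a limit)
compound 2 `Cc1cc2c(cc1C)C(Cl)=C(/C=N/NC(=O)c1cccc(Cl)c1)CCC2` — 33600 nM

Among the compounds with values here, in a functional assay (MiaPaCa cells, Homo sapiens) for inhibition, read by sulforhodamine B assay, with a stated time of 48 h (on this read-out higher numbers stand for weaker inhibition of growth and lower numbers for stronger inhibition of growth), compound 2 gives 33600 nM, the only number in the set. Compound 1 gives only a limit, > 100000 nM. Within the data shown here, the single measured step, an at least 2.9-fold lower number from compound 1 to compound 2 (0.47 log units; beyond the scatter), is bounded by the limit of > 100000 nM in this assay, at which 1 of the 2 values shown sits. Compound 3 `Cc1cc2c(cc1C)C(Cl)=C(/C=N/NC(=O)c1cccnc1)CCC2` differs from compound 2 by pyridin-3-yl in place of 3-chlorophenyl on a carbonyl carbon. This removes the chloro whose introduction gave an at least 2.9-fold lower number from compound 1 to compound 2 (0.47 log units; beyond the scatter), and nothing measured here speaks for the entering group, so weaker inhibition is expected, a step of a 2.1-fold higher number from compound 2 to compound 3 (0.32 log units; beyond the scatter). Compound 3 is therefore estimated at 70000 nM, range 20000 nM to 200000 nM, with a real chance of only a limit.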

Compound 3, concentration for 50% growth inhibition: 1600 nM
Compound 3: the middle estimate sits 44-fold (1.64 log units) above what was measured; the measured number lies below the stated range.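

At this carbonyl carbon, the ring itself matters far more than the chloro step suggested: in this assay there is a 21-fold lower number from compound 2 to compound 3 (1.32 log units; beyond the scatter), with pyridin-3-yl in place of 3-chlorophenyl. Against the unsubstituted phenyl, the change gives an at least 62-fold lower number from compound 1 to compound 3 (1.79 log units; beyond the scatter). The value of compound 1 is a limit, so this step is a bound and not a measured size: the limit of > 100000 nM in this assay, at which 1 of the 3 values shown sits.

Still open, on these data alone, is whether a pyridin-4-yl or pyrimidin-5-yl group on the same carbonyl carbon would hold this level. As far as these compounds go, whether a chloro on the pyridin-3-yl ring would add to it is also open.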